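The compounds below may be only part of what the source reports. "The series", "measured", "known", "first", "only" and "open" are said of these compounds alone.

Of the compounds shown here, three from one series have been tested in a functional assay on the whole organism (strain CD-1) with Mus musculus as the target, in the maximal electroshock model, with a stated time of 0.5 h (a lower number here means that less compound is needed, a higher number that more compound is needed for the effect), all sharing the same core. Compound 1, `CC1(c2ccccc2)CC(=O)N(CC(=O)N2CCN(c3ccccc3F)CC2)C1=O`, carries a 2-fluorophenyl on an amine nitrogen in a ring, and in this assay compound 1 gives 100 mg/kg. Compound 3, `CC1(c2ccccc2)CC(=O)N(CC(=O)N2CCN(c3cccc(Cl)c3)CC2)C1=O`, carries a 3-chlorophenyl in the same place, and compound 3 gives 300 mg/kg. Compound 2, `CC1(c2ccccc2)CC(=O)N(CC(=O)N2CCN(c3ccc(Cl)cc3)CC2)C1=O`, carries a 4-chlorophenyl there, and compound 2 was reported as "not active" (no number reported), so no number exists for it. For the measured compounds named here, of the two numbers, compound 1 stands lowest, and the only measured step is a 3.0-fold higher number from compound 1 to compound 3 (0.48 log units; beyond the scatter).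

Compound 4, `COc1ccccc1N1CCN(C(=O)CN2C(=O)CC(C)(c3ccccc3)C2=O)CC1`, differs from compound 1 in one place: methoxy in place of fluoro on an aromatic carbon. The change keeps the group where the fluorine was, on the aromatic carbon ortho to the large group, so it does not follow the move of the halogen seen between compound 1 and compound 3. Going by the values given here, no measured step speaks to a methoxy in this position. Among the compounds with values here, the one step in hand is modest, and the change here is smaller in kind, so the expected step is a 1.5-fold higher number from compound 1 to compound 4 (0.18 log units; within the scatter), likely within the scatter. Compound 4 is therefore estimated at 150 mg/kg, with a range from 60 mg/kg to 400 mg/kg.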

Compound 4, minimum effective dose: 100 mg/kg
Compound 4: middle estimate off by 1.5-fold (0.18 log units), on the high side; the range from low to high includes it.
By their numbers in this assay, from the lowest: compounds 1 and 4 (each within the scatter of the next); then compound 3.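

Putting methoxy, with 2 heavy atoms and 1 hydrogen-bond acceptor, in place of fluoro on this aromatic carbon gives no change at the digits printed from compound 1 to compound 4 (within the scatter) in this assay, so at this level of measurement the two groups cannot be told apart. The 2-methoxyphenyl group of compound 4 also stands apart from the 3-chlorophenyl group, with a 3.0-fold lower number from compound 3 to compound 4 (0.48 log units; beyond the scatter), which means that the gap first seen with compound 1 now appears with a second group on the same ring carbon. Nothing available gives a reason for these numbers.

Compound 1 and compound 3 differ in both the halogen and its place on the ring, so the compounds shown cannot separate these two changes, and steps involving compound 2 cannot be read since it has no number. As far as these compounds go, it also remains open whether the match between fluoro and methoxy would hold for a longer chain such as ethoxy, or for an amine, on this aromatic carbon.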